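A few compounds are considered here, and "the series" means these few. Any claim that something is new, unique, unknown or untested is made for them only; others in the source may bear on it.

Of the compounds shown here, three have been measured in a functional assay on T47D cells (Homo sapiens) for inhibition, read by CCK-8 assay, with a stated time of 72 h, tested at 1 uM; a higher number here means more inhibition of growth at the concentration tested, a lower number less inhibition of growth. Compound 2 `COc1ccc(NC(=O)C2(C(=O)Nc3ccc(Nc4ncc5cc(C(=O)N(C)C)n(C6CCCC6)c5n4)cc3)CC2)cc1` gives 76.4%, the highest of the three numbers. Compound 1 `CN(C)C(=O)c1cc2cnc(Nc3ccc(N)cn3)nc2n1C1CCCC1` gives 18.8%, a result lower by a margin beyond the usual scatter, and compound 3 `Nc1ccc(NC(=O)C2(C(=O)Nc3ccc(F)cc3)CC2)cc1F` gives 5.6%, lower still and also beyond the scatter. Compound 4 `CN(C)C(=O)c1cc2cnc(Nc3ccc(NC(=O)C4(C(=O)Nc5ccccc5)CC4)cc3)nc2n1C1CCCC1` has not yet been measured. It differs from compound 2 in a single place: hydrogen in place of methoxy on an aromatic carbon. Going by the values given here, no pair of measured compounds shows this change, so its effect here is unknown. Swapping a methoxy group for a hydrogen atom on an aromatic carbon is a small alteration, and in this assay the step is expected to be small, either none beyond the scatter or a modest drop. Compound 4 is therefore expected to give about 70%, within 50% to 88%. The expected step is a number 6.4 percentage points lower from compound 2 to compound 4 (within the scatter).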

Compound 4, percent growth inhibition at one concentration: 52.8%
Compound 4: middle estimate off by 17.2 percentage points, on the high side, within the range that was stated.
By their numbers in this assay, from the lowest: compound 3; then compound 1; then compound 4; then compound 2.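

In this assay, replacing methoxy with hydrogen gives a number 23.6 percentage points lower from compound 2 to compound 4 (beyond the scatter), so the group on this aromatic carbon, para to a large group, clearly affects the result. The position is therefore sensitive to this change, although compound 4, with only hydrogen there, still gives 52.8%. No available measurement accounts for the step.

Whether this effect is specific to methoxy remains open, since the compounds shown include no other group at this position. A hydroxyl group, an ethoxy group or a chlorine atom there could show whether the number follows the methoxy group or changes with other replacements.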